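The source may report more compounds than this note shows. Statements on the series, on what has been measured and on what is new or still open speak of the compounds shown alone.

Measured so far:
compound 1 `O=C(/C(=C\c1ccc(O)c([N+](=O)[O-])c1)SCc1ccccc1Cl)c1ccc(Cl)cc1`: 10000 nM
compound 2 `O=C(/C(=C\c1ccc(O)c([N+](=O)[O-])c1)Sc1ccccc1Br)c1ccc(Br)cc1`: 10000 nM

Both values come from a functional assay on DU-145 cells (Homo sapiens) for inhibition, read by trypan blue exclusion, with a stated time of 96 h; on this read-out lower numbers stand for stronger inhibition of growth and higher numbers for weaker inhibition of growth. At the digits shown, compound 2 stands level with compound 1, and compound 2 reads 10000 nM. The two lie within the scatter of each other. Within the data shown here, no two measured compounds differ in only one place, so the series offers no measured step to draw on.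

Compound 3 `O=C(/C(=C\c1ccc(O)c([N+](=O)[O-])c1)Sc1ccccc1Br)c1ccc(Cl)cc1` awaits measurement in this assay. It differs from compound 2 at a single site: chloro in place of bromo on an aromatic carbon. This is chloro in place of bromo on an aromatic carbon, para to a large group, so that 4-bromophenyl becomes 4-chlorophenyl. Among the measured compounds shown here, no measured pair tests this exchange directly. Compound 1 already carries the (4-chlorophenyl)carbonyl group and gives 10000 nM, which offers only indirect support for expecting no shift, since it differs from compound 3 elsewhere too.

The expected step is none beyond the scatter, with no favoured direction, and the estimate is no change at the digits printed from compound 2 to compound 3 (within the scatter). The estimate for compound 3 is 10000 nM, with an expected range of 4000 nM to 20000 nM.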

Compound 3, concentration for 50% growth inhibition: 25000 nM
Compound 3: middle estimate off by 2.5-fold (0.40 log units), on the low side; the measured number lies above the stated range.
By their numbers in this assay, from the lowest: compounds 1 and 2 (each within the scatter of the next); then compound 3.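

In this assay, chloro in place of bromo on an aromatic carbon, para to a large group, gives a 2.5-fold higher number from compound 2 to compound 3 (0.40 log units; beyond the scatter), making 4-bromophenyl to 4-chlorophenyl a change at this position that moves the number beyond the scatter, towards weaker inhibition of growth. With the (4-chlorophenyl)carbonyl group common to both compounds, 2-bromophenyl in place of 2-chlorobenzyl on a sulfur gives a 2.5-fold higher number from compound 1 to compound 3 (0.40 log units; beyond the scatter), so the group on the sulfur also shifts the number beyond the scatter. Nothing available here bears on why either change moves the read-out.

As far as these compounds go, what a fluoro, a methoxy or an amine on that same aromatic carbon would do to the number remains open, as does whether the step from bromo to chloro would recur with the 2-chlorobenzyl group on the sulfur in place of 2-bromophenyl. Also open is whether a carboxylic acid or a longer chain on the sulfur would give stronger inhibition of growth than the groups on the sulfur shown so far.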